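From ethyl to butyl: a step still unmeasured

The compounds below may be only part of what the source reports. "The series", "measured", "known", "first", "only" and "open" are said of these compounds alone.

Three related compounds have so far been measured in a functional assay (aorta) for inhibition, with Rattus norvegicus as the target (a lower number here means a stronger inhibitor, a higher number a weaker inhibitor), and their numbers are well spread. Compound 1 `C/N=C(\S)[C@]1(c2cccc(C#N)c2)CCCC[S+]1[O-]` gives 1600 nM in this test, and compound 2 `C/N=C(\S)[C@]1(c2cccc(F)c2)CCCC[S+]1[O-]` gives 7000 nM in the same test. Compound 3 `CC/N=C(\S)[C@]1(c2cccnc2)CCCC[S+]1[O-]` gives 300 nM as the lowest of the three numbers, clear of the other two beyond the scatter.

Compound 4 `CCCC/N=C(\S)[C@]1(c2cccnc2)CCCC[S+]1[O-]` has not yet been measured. Its difference from compound 3 is ethyl in place of hydrogen on a saturated chain carbon, two bonds along the chain from a double-bonded nitrogen and in words it is ethyl in place of hydrogen on a saturated chain carbon, two bonds along the chain from a double-bonded nitrogen, so that ethyl becomes butyl.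

Among the compounds with values here, no measured step touches this chain. Within the data shown here, the only single-place step is a 4.4-fold higher number from compound 1 to compound 2 (0.64 log units; beyond the scatter) with fluoro in place of cyano on an aromatic carbon, a modest change elsewhere in the molecule that offers only a rough guide to size. A step of similar size is therefore expected, toward a higher number, though this is uncertain. For compound 4 the estimate is an expected 5.0-fold higher number from compound 3 to compound 4 (0.70 log units; beyond the scatter) on present evidence. The estimated value for compound 4 is 1500 nM with an expected range from 400 nM to 6000 nM at this stage.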

Compound 4, concentration for 90% inhibition: 8000 nM
The estimate for compound 4 lay 5.3-fold (0.73 log units) below the measured number; measured number outside the range, above it.
By their numbers in this assay, from the lowest: compound 3; then compound 1; then compounds 2 and 4 (each within the scatter of the next).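

With everything else held as in compound 3, ethyl in place of hydrogen on a saturated chain carbon, two bonds along the chain from a double-bonded nitrogen, turns ethyl into butyl and gives a 27-fold higher number from compound 3 to compound 4 (1.43 log units; beyond the scatter) in this assay. Within the data shown here, this is the first step measured on this chain, and its large size shows that the number in this test can depend strongly on the chain's length, something the earlier change on an aromatic carbon could not reveal. No experimental evidence at hand accounts for the step, so its cause remains unknown.

With only ethyl and butyl shown on this aromatic group, the compounds leave open whether propyl would fall closer to compound 3 or to compound 4, and so whether the number climbs gradually along the chain or jumps at one length. They also leave open how a longer chain such as hexyl, or a chain ending in an amine or a carboxylic acid, would read in this assay, and whether the same lengthening would give a step of similar size with the cyano or fluoro groups of compound 1 and compound 2.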